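From butylamino to pyrrolidin-1-yl on a carbonyl carbon

This account rests on a few compounds, and the source may have more. Where it says the series, first, only, none or still open, it means among the compounds named here.

For the measured compounds named here, in a functional assay on A549 cells (Homo sapiens) for inhibition, read by sulforhodamine B assay, with a stated time of 72 h (on this read-out higher numbers stand for weaker inhibition and lower numbers for stronger inhibition), compound 2 (`CCCCNC(=O)c1c(N)sc(-c2ccc(Cl)cc2)c1-c1ccc(Cl)cc1`) gives 8170 nM, the higher of the two numbers so far, while compound 1 (`Nc1sc(-c2ccc(Cl)cc2)c(-c2ccc(Cl)cc2)c1C(=O)N1CCCCC1=O`) gives 1820 nM. Compound 3 (`Nc1sc(-c2ccc(Cl)cc2)c(-c2ccc(Cl)cc2)c1C(=O)N1CCCC1`) has pyrrolidin-1-yl in place of butylamino on a carbonyl carbon. Going by the values given here, the only measured step that bears on this is modest: a 4.5-fold higher number from compound 1 to compound 2 (0.65 log units; beyond the scatter), where butylamino replaced 2-oxopiperidin-1-yl. Compound 3 regains a ring, as in compound 1, so part of that step is expected to reverse, giving an estimated 2.3-fold lower number from compound 2 to compound 3 (0.37 log units; beyond the scatter). For compound 3 the estimated value is 3500 nM, with an expected range of 1200 nM to 10000 nM.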

Compound 3, half-maximal inhibitory concentration: 890 nM
Estimate against measurement, compound 3: 3.9-fold (0.59 log units) above; the whole stated range lies above it.
By their numbers in this assay, from the lowest: compound 3; then compound 1; then compound 2.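

Replacing butylamino with pyrrolidin-1-yl keeps the heavy-atom count but adds a ring and removes the hydrogen-bond donor, and it gives a 9.2-fold lower number from compound 2 to compound 3 (0.96 log units; beyond the scatter) in this assay, so the number at this carbonyl carbon can shift without any change in group size. The ring also needs no carbonyl of its own, as replacing 2-oxopiperidin-1-yl with pyrrolidin-1-yl gives a 2.0-fold lower number from compound 1 to compound 3 (0.31 log units; beyond the scatter). No evidence is available on the cause of either step. The compounds shown cannot separate the effect of the ring from the loss of the amide hydrogen. Dimethylamino, which has no ring and no amide hydrogen, would separate them, while piperidin-1-yl would test ring size.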